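Fluorine added to the cyanophenyl arm of the thiazole series

The source may hold more compounds than are shown below. What is called first, only, known or untested is meant among the compounds shown, and "the series" means these compounds.

Measured compounds:
compound 1 `O=C(O)Cc1sc(C(c2ccc(F)cc2)c2ccc(F)cc2)nc1-c1ccccc1` gives 240 nM in an in vitro functional assay on HEK285-7 cells for antagonist activity at prostaglandin D2 receptor 2 (Homo sapiens), read by BRET and beta-arrestin recruitment; a higher number here means a weaker inhibitor, a lower number a stronger inhibitor
compound 2 `O=C(O)Cc1sc(C(c2ccc(F)cc2)c2ccc(F)cc2)nc1-c1cccc(F)c1` gives 18 nM in this assay
compound 3 `N#Cc1ccc(-c2nc(C(c3ccc(F)cc3)c3ccc(F)cc3)sc2CC(=O)O)cc1` gives 1500 nM in this assay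

Compound 3 carries the highest number of the three in this assay; compound 1 sits nearest, compound 2 furthest, and both gaps lie beyond the scatter. The step to compound 4 `N#Cc1cc(-c2nc(C(c3ccc(F)cc3)c3ccc(F)cc3)sc2CC(=O)O)ccc1F` is 3-cyano-4-fluorophenyl in place of 4-cyanophenyl on an aromatic carbon.

Among the compounds with values here, two measured steps bear on this. The closest is a 13-fold lower number from compound 1 to compound 2 (1.12 log units; beyond the scatter), a fluoro added on an aromatic carbon of the same arm, which lowered the number strongly. The cyano addition itself, a 6.3-fold higher number from compound 1 to compound 3 (0.80 log units; beyond the scatter), raised it, and an 83-fold higher number from compound 2 to compound 3 (1.92 log units; beyond the scatter) shows how far the cyanophenyl analogue lies from the fluorophenyl one. Compound 4 keeps the cyano and adds the fluoro, so a lowering from compound 3 is expected, though whether it reaches the full size seen with compound 2 is uncertain, since the fluoro now enters a ring that already bears a cyano.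

The estimate for compound 4 in this assay is 400 nM (range 100 nM to 1500 nM), meaning an expected step of a 3.8-fold lower number from compound 3 to compound 4 (0.57 log units; beyond the scatter).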

Compound 4, half-maximal inhibitory concentration: 520 nM
For compound 4 the middle estimate is 1.3-fold (0.11 log units) below the measured one, within the range that was stated.
By their numbers in this assay, from the lowest: compound 2; then compound 1; then compound 4; then compound 3.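

In this assay, the 3-cyano-4-fluorophenyl arm gives back only part of what the nitrile cost, with a modest step (a 2.9-fold lower number from compound 3 to compound 4 (0.46 log units; beyond the scatter)), whereas the fluoro change on the plain phenyl arm was large (a 13-fold lower number from compound 1 to compound 2 (1.12 log units; beyond the scatter)). The arm remains well short of 3-fluorophenyl (a 29-fold higher number from compound 2 to compound 4 (1.46 log units; beyond the scatter)) and also short of plain phenyl (a 2.2-fold higher number from compound 1 to compound 4 (0.34 log units; beyond the scatter)), so in this set both nitrile-bearing arms carry higher numbers than the unsubstituted one. The step also combines two changes, since the nitrile stands elsewhere on the ring as well as a fluorine entering it, and the set cannot divide the gain between them.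

A 3-cyanophenyl or 4-fluorophenyl arm would separate those two contributions, and a 3-chlorophenyl arm would show whether the low number of compound 2 is specific to fluorine. No measurement at hand bears on the cause of these steps.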